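The source may report more compounds than this note shows. Statements on the series, on what has been measured and on what is new or still open speak of the compounds shown alone.

Series notes. Compound 3 `N#Cc1nc2c(-c3nc4ccccc4[nH]3)c(N)n(CCO)c2nc1C#N` carries a hydroxy on a saturated chain carbon, two bonds along the chain from an aromatic nitrogen. In a functional assay on A549 cells (Homo sapiens) for antiproliferative activity, read by MTT assay, with a stated time of 48 h (on this read-out lower numbers stand for stronger inhibition and higher numbers for weaker inhibition), compound 3 gives only the limit > 50000 nM. Compound 1 `CN(C)CCn1c(N)c(-c2nc3ccccc3[nH]2)c2nc(C#N)c(C#N)nc21` in this assay likewise gives only the limit > 50000 nM. Compound 2 `CCN(CC)CCn1c(N)c(-c2nc3ccccc3[nH]2)c2nc(C#N)c(C#N)nc21` also returns only the limit > 50000 nM in this assay. All three values sit at the limit of > 50000 nM in this assay, at which 3 of the 3 values shown sit, so compound 3 stands level with the other two as far as the numbers allow, and the steps a step that the two limits leave unreadable from compound 1 to compound 2, a step that the two limits leave unreadable from compound 1 to compound 3 and a step that the two limits leave unreadable from compound 2 to compound 3 cannot be sized.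

Compound 4 `CCN(CC)CCCCn1c(N)c(-c2nc3ccccc3[nH]2)c2nc(C#N)c(C#N)nc21` differs from compound 3 by 2-(diethylamino)ethyl in place of hydroxy on a saturated chain carbon, two bonds along the chain from an aromatic nitrogen, the hydroxy leaving and the 2-(diethylamino)ethyl entering. Of the measured steps, a step that the two limits leave unreadable from compound 2 to compound 3 bears most closely on this change, exchanging diethylamino and hydroxy at the same place, but its size is unreadable. No step beyond the scatter is expected in this assay, the expected step being a step that the limit leaves unreadable from compound 3 to compound 4. Compound 4 is estimated at 80000 nM, within 20000 nM to 300000 nM, most likely again returned as a limit.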

Compound 4, half-maximal inhibitory concentration: 5750 nM
Beside the measured number, compound 4's estimate is 14-fold (1.14 log units) above it, and the stated range ends above it.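

In this assay, among the compounds shown here, 2-(diethylamino)ethyl in place of hydroxy on this saturated chain carbon gives an at least 8.6-fold lower number from compound 3 to compound 4 (0.93 log units; beyond the scatter), the first change at this position that can be sized, and then only as a bound. The same group gives an at least 8.6-fold lower number from compound 2 to compound 4 (0.93 log units; beyond the scatter) and an at least 8.6-fold lower number from compound 1 to compound 4 (0.93 log units; beyond the scatter); compound 2 and compound 4 both end in diethylamino, so that end group on the shorter chain of compound 2 is not enough to produce a readable value, whereas on the longer chain of compound 4 it does. The steps among compound 1, compound 2 and compound 3 remain unreadable, and compound 4 alone leaves the limit: the limit of > 50000 nM in this assay, at which 3 of the 4 values shown sit.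

As far as these compounds go, whether the longer chain suffices without the amine stays open, and a butyl chain ending in hydroxy would test this. A propyl chain ending in diethylamino, or a still longer chain, would show how the value follows chain length.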